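A few compounds are considered here, and "the series" means these few. Any claim that something is new, unique, unknown or untested is made for them only; others in the source may bear on it.

Measured compounds:
compound 1 `CC1=C(C(=O)OCc2ccccc2)C(c2ccoc2)NC(=S)N1`: 25%
compound 2 `COC(=O)C1=C(C)NC(=S)NC1c1cccs1`: 1%
compound 3 `CCCOC(=O)C1=C(C)NC(=S)NC1c1cccs1`: 7%

In an assay on membranes from CHO cells for displacement of a labelled ligand from adenosine receptor A1 (Homo sapiens), read by scintillation counting, with a stated time of 60 min, tested at 1 uM (a higher number here means more inhibition at the concentration tested (going by the name of the read-out), a lower number less inhibition), compound 3 gives 7%, the second highest of the three numbers; compound 2 is nearest with 1%, within the scatter, while compound 1 is furthest with 25%, beyond it. Compound 4 `CC1=C(C(=O)OCc2ccccc2)C(c2cccs2)NC(=S)N1` differs from compound 3 in one place: phenyl in place of ethyl on a saturated chain carbon bound to an oxygen next to a carbonyl group. For the measured compounds named here, the only measured step at this place is a number 6 percentage points higher from compound 2 to compound 3 (within the scatter), which does not reach the phenyl group. Compound 1 also carries the benzyl group but differs from compound 3 in a second place as well; compound 1 gives 25%. The step of a number 11 percentage points higher from compound 3 to compound 4 (beyond the scatter) is therefore expected to be a modest rise, with wide uncertainty. Compound 4 is estimated at 18%, in the range 5% to 35%.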

Compound 4, a percentage reported as inhibition, at one concentration (the size of the read-out at that concentration, not a potency): 34%
The estimate for compound 4 lay 16 percentage points below the measured number, and the stated range covers the measured number.
By their numbers in this assay, from the lowest: compounds 2 and 3 (each within the scatter of the next); then compounds 1 and 4 (each within the scatter of the next).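

In this assay the phenyl group on the saturated chain carbon bound to an oxygen next to a carbonyl group brings a number 27 percentage points higher from compound 3 to compound 4 (beyond the scatter) and a number 33 percentage points higher from compound 2 to compound 4 (beyond the scatter) while the earlier ethyl step stayed within the scatter, so this place does respond once phenyl enters. With phenyl present, the saturated ring carbon gives a number 9 percentage points higher from compound 1 to compound 4 (within the scatter) so thiophen-2-yl and furan-3-yl cannot be told apart here. Nothing available gives a reason for the rise. Going by these compounds, whether a cyclohexyl ring, a longer chain or an amine at this place would do the same stays open.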